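This account rests on a few compounds, and the source may have more. Where it says the series, first, only, none or still open, it means among the compounds named here.

Compounds measured so far in an assay on cells for agonist activity at ecdysone receptor (Bombyx mori), read by a luciferase reporter, with a stated time of 24 h; a lower number here means that less compound is needed, a higher number that more compound is needed for the effect:
compound 1 `CC(C)(C)N(NC(=O)c1ccccc1)C(=O)c1ccccc1F` with 309 nM
compound 2 `CC(C)(C)N(NC(=O)c1ccccc1)C(=O)c1ccccc1Cl` with 75.9 nM
compound 3 `COc1cccc(C(=O)NN(C(=O)c2ccccc2Cl)C(C)(C)C)c1` with 52.5 nM

Compound 2 stands apart from compound 1 by a 4.1-fold lower number from compound 1 to compound 2 (0.61 log units; beyond the scatter), a change of chloro in place of fluoro on an aromatic carbon, whereas compound 2 and compound 3 lie within the usual scatter of one another, as the step of a 1.4-fold lower number from compound 2 to compound 3 (0.16 log units; within the scatter) shows. Compound 4 `CC(C)c1ccc(C(=O)NN(C(=O)c2ccccc2Cl)C(C)(C)C)cc1` differs from compound 2 by isopropyl in place of hydrogen on an aromatic carbon. Within the data shown here, of the measured steps, the one from compound 2 to compound 3 bears most directly, since it also puts a group onto an aromatic carbon of the same ring and stays within the scatter; the step from compound 1 to compound 2 concerns the other ring and is less informative. The author therefore expects at most a small step in this assay, if any, toward a lower number. For compound 4 the estimate in this assay is 50 nM, with a range from 15 nM to 160 nM, which is expected to correspond to a 1.5-fold lower number from compound 2 to compound 4 (0.18 log units; within the scatter).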

Compound 4, half-maximal effective concentration: 24.6 nM
Compound 4: middle estimate off by 2.0-fold (0.31 log units), on the high side, within the range that was stated.
By their numbers in this assay, from the lowest: compound 4; then compounds 3 and 2 (each within the scatter of the next); then compound 1.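

Placing isopropyl in place of hydrogen, para to a large group, gives a 3.1-fold lower number from compound 2 to compound 4 (0.49 log units; beyond the scatter) in this assay, so a substituent on this ring can move the number beyond the scatter. The earlier methoxy change on the same ring had not shown this, since it gave only a 1.4-fold lower number from compound 2 to compound 3 (0.16 log units; within the scatter), within the scatter. Nothing shown gives a measured reason for the size of the isopropyl step.

The compounds shown leave open whether this step belongs to isopropyl itself or to any group at this carbon, a question that methyl, tert-butyl, methoxy or a carboxylic acid at the same carbon would address. They also leave open whether isopropyl gives a similar step with fluoro in place of chloro on the other ring.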